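This account rests on a few compounds, and the source may have more. Where it says the series, first, only, none or still open, it means among the compounds named here.

Two of the three compounds in this set have been put through an in vitro functional assay on HEK293-A cells for antagonist activity at metabotropic glutamate receptor 5 (Rattus norvegicus), read by calcium flux; a higher number here means a weaker inhibitor, a lower number a stronger inhibitor. Going by the values given here, compound 2, with the structure `O=C(Nc1cccc(NC(=O)C2CCC2)c1)c1cccc(Cl)c1`, gives 5270 nM; it is the only compound among those measured that yields a number rather than a limit. Compound 1, with the structure `O=C(Nc1cccc(NC(=O)c2ccc(Cl)c(Cl)c2)c1)c1cccc(Cl)c1`, gives > 30000 nM, and this reading is a limit of the assay, not a number. That is the basis of the limit of > 30000 nM in this assay, at which 1 of the 2 values shown sits. Among the compounds with values here, the single measured step goes from compound 1 to compound 2: an at least 5.6-fold lower number from compound 1 to compound 2 (0.75 log units; beyond the scatter), the change there being cyclobutyl in place of 3,4-dichlorophenyl on a carbonyl carbon.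

Compound 3 has the structure `COCC(=O)Nc1cccc(NC(=O)c2cccc(Cl)c2)c1`. It differs from compound 2 by methoxymethyl in place of cyclobutyl on a carbonyl carbon. No measured step bears directly on this exchange: the one step shown swaps the group on that same carbonyl carbon, but between different groups, so it offers only a loose guide. The expectation for compound 3 in this assay is therefore a change of a 1.5-fold higher number from compound 2 to compound 3 (0.18 log units; within the scatter), small enough to sit near the scatter. Compound 3 is estimated at 8000 nM, within the range 2500 nM to 30000 nM.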

Compound 3, half-maximal inhibitory concentration: > 30000 nM
Compound 3 ended at the assay's limit (the forecaster's own chance of this, stated with the estimate: 25%); at least 3.7-fold (0.57 log units) between middle value and limit.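

Compound 2 turns out to be sensitive to the group on this carbonyl carbon: in this assay, methoxymethyl in place of cyclobutyl gives an at least 5.6-fold higher number from compound 2 to compound 3 (0.75 log units; beyond the scatter). Going by these compounds alone, the one earlier step showed only that cyclobutyl did better than 3,4-dichlorophenyl at this place, and compound 3 now shows that leaving 3,4-dichlorophenyl behind is not enough to give a measurable number, since a group with no ring and one hydrogen-bond acceptor also ends at the limit. The step between compound 1 and compound 3 cannot be read, so these two cannot be ranked, and cyclobutyl remains the only group at this place that gives a number: the limit of > 30000 nM in this assay, at which 2 of the 3 values shown sit.

The compounds shown leave open whether the loss goes with losing the four-membered ring or with bringing in the oxygen, and a plain propyl chain, with neither ring nor oxygen, would help to separate the two. Going by these compounds, how the number responds to ring size on this carbonyl carbon also stays open, for example with a cyclopropyl or a cyclopentyl ring in place of cyclobutyl.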